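Extending a carboxy chain from a dihydroxy ether on the core

This account rests on a few compounds, and the source may have more. Where it says the series, first, only, none or still open, it means among the compounds named here.

Compound 3 `O=c1c(-c2ccc(O)cc2)coc2cc(OCC(O)CO)ccc12` stands second highest of the three measured compounds in a functional assay on mitochondria (Cricetulus griseus) for inhibition of Monoamine oxidase (Homo sapiens), tested at 0.9 uM (a higher number here means a stronger effect of the compound at the concentration tested, a lower number a weaker effect), where compound 3 gives 63.8%. Its nearest neighbour is compound 1 `O=c1c(-c2ccc(O)cc2)coc2cc(OCCCCBr)ccc12`, which in this assay gives 55.3%, a gap within the scatter. The furthest is compound 2 `O=C(O)CCCCCCCCCOc1ccc2c(=O)c(-c3ccc(O)cc3)coc2c1`, which in this assay gives 85.1%, a gap beyond the scatter.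

Compound 4 `O=C(O)CCCCCCOc1ccc2c(=O)c(-c3ccc(O)cc3)coc2c1` differs from compound 3 in one place: 5-carboxypentyl in place of 1,2-dihydroxyethyl on a saturated chain carbon bound to an oxygen on an aromatic ring. Among the measured compounds shown here, the one measured step that bears on this change is a number 29.8 percentage points higher from compound 1 to compound 2 (beyond the scatter), where a 5-carboxypentyl group also entered the chain and the number rose beyond the scatter. Compound 4 carries the same carboxy-terminated chain as compound 2, though shorter, so a rise toward the value of compound 2 is expected, of a modest size, as a number 13.2 percentage points higher from compound 3 to compound 4 (beyond the scatter). For compound 4 the estimated value in this assay is 77%, in a range from 64% to 90%.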

Compound 4, a percentage reported as inhibition, at one concentration (the size of the read-out at that concentration, not a potency): 71.2%
Estimate against measurement, compound 4: 5.8 percentage points above; the measured number falls inside the stated range.
By their numbers in this assay, from the lowest: compounds 1, 3 and 4 (each within the scatter of the next, the first and the last beyond it); then compound 2.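

In this assay, putting 5-carboxypentyl in place of 1,2-dihydroxyethyl on the saturated chain carbon bound to an oxygen on an aromatic ring does not separate the two compounds (a number 7.4 percentage points higher from compound 3 to compound 4 (within the scatter)). Chain length on the carboxy-terminated ethers does separate them: carboxy in place of 3-carboxypropyl gives a step beyond the scatter (a number 13.9 percentage points lower from compound 2 to compound 4 (beyond the scatter)), and the shorter acid also stands clear of the bromo-ended chain (a number 15.9 percentage points higher from compound 1 to compound 4 (beyond the scatter)). Nothing measured here explains these steps.

The compounds shown leave open whether a still longer chain ending in a carboxylic acid, or a chain shorter than 5-carboxypentyl, would move the number further. They also leave open whether an amine or a methyl ester at the chain end would do as well as the acid.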